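Removing the Chloro Group from a Weakly Cytotoxic Scaffold

This account rests on a few compounds, and the source may have more. Where it says the series, first, only, none or still open, it means among the compounds named here.

Compound 1 `CC1(C)OC2O[C@@H](Cc3cn4cc(Cl)ccc4nc3=O)C(OCc3ccccc3)C2O1` was tested in a functional assay on MCF7 cells (Homo sapiens) for cytotoxicity, read by MTT assay, with a stated time of 24 h; a lower number here means a stronger inhibitor, a higher number a weaker inhibitor. In this assay compound 1 gives only a limit, > 1000000 nM, and no number. Two other compounds have also been measured: compound 2 `O=c1nc2ccccn2cc1Cc1ccc(Br)cc1` gives 157000 nM in this assay, and compound 3 `Nc1cc(Br)cn2cc(Cc3ccc(F)cc3C(F)(F)F)c(=O)nc12` gives 151000 nM, the two lying within the scatter of each other. Compound 1 sits at the limit of > 1000000 nM in this assay, at which 1 of the 3 values shown sits. Compound 4 `CC1(C)OC2O[C@@H](Cc3cn4ccccc4nc3=O)C(OCc3ccccc3)C2O1` has not yet been measured; it differs from compound 1 in one place: hydrogen in place of chloro on an aromatic carbon. Going by the values given here, no step between measured compounds is known, so no direction can be taken from the data, and the change is expected to stay within the scatter. Compound 4 is expected to give about 1000000 nM in this assay, between 200000 nM and 5000000 nM, probably again as a limit. The expected step of a number no higher from compound 1 to compound 4 (the limit leaves the size open) is estimated as no change beyond the scatter.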

Compound 4, half-maximal inhibitory concentration: > 1000000 nM
Compound 4: no number, only a limit (the forecaster's own chance of this, stated with the estimate: 70%); the middle value lies on the limit itself.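

No step can be read from compound 1 to compound 4, since each gives only a limit and no number: the limit of > 1000000 nM in this assay, at which 2 of the 4 values shown sit.

The compounds shown leave open whether hydrogen in place of chloro changes the value at all.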